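A few compounds are considered here, and "the series" means these few. Any claim that something is new, unique, unknown or untested is made for them only; others in the source may bear on it.

In a functional assay on NCI-H23 cells (Homo sapiens) for cytotoxicity, read by sulforhodamine B assay, with a stated time of 72 h (a higher number here means a weaker inhibitor of growth, a lower number a stronger inhibitor of growth), the measured compounds stand as follows.
Compound 1, `O=C(Nc1ccccc1O)C1CCc2ccccc2N1C(=O)c1ccccc1Cl`, gives 46900 nM.
Compound 2, `CC(=O)N1c2ccccc2CCC1C(=O)Nc1cc(C(F)(F)F)cc(C(F)(F)F)c1`, gives > 70000 nM, which is a limit of the assay and not a number.
Compound 3, `CCCCCCCCC(=O)N1c2ccccc2CCC1C(=O)Nc1ccccc1C(F)(F)F`, gives 4220 nM.

Compound 3 has the lowest of the two actual numbers in this assay; compound 1 sits at a number higher by a gap well beyond the usual scatter. Compound 2 stands only at the limit of > 70000 nM in this assay, at which 1 of the 3 values shown sits.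

Compound 4, `O=C(Nc1ccccc1C(F)(F)F)C1CCc2ccccc2N1C(=O)c1cccc(Cl)c1`, has not yet been measured. It differs from compound 3 in one place: 3-chlorophenyl in place of octyl on a carbonyl carbon. Within the data shown here, no measured pair shows this same exchange on its own, so its effect here is unknown. Among the measured compounds shown here, compound 1, the only measured compound carrying an aromatic ring rather than a chain on that carbonyl carbon, gives a higher number than compound 3, but the two also differ elsewhere, so their values can only be set side by side, not read as the effect of this change.

Trading the long chain for a ring is expected to raise the number moderately, as a step of a 3.6-fold higher number from compound 3 to compound 4 (0.55 log units; beyond the scatter), with wide uncertainty. Compound 4 is therefore estimated at 15000 nM, within a range from 4000 nM to 60000 nM.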

Compound 4, concentration for 50% growth inhibition: 292 nM
Compound 4: the middle estimate sits 51-fold (1.71 log units) above what was measured; measured number below the stated range.
By their numbers in this assay, from the lowest: compound 4; then compound 3; then compound 1. At a limit, above all of these: compound 2.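

In this assay, among these compounds, placing 3-chlorophenyl instead of octyl on the carbonyl carbon attached to the ring amide nitrogen gives a 14-fold lower number from compound 3 to compound 4 (1.16 log units; beyond the scatter), and this is the first reading of a change at this position with everything else in the molecule held the same. It shows that a long, flexible chain is not needed here for a low number: in this pair, a six-membered aromatic ring carrying a chlorine gives a far stronger inhibitor of growth than octyl, with the rest of the structure untouched. Nothing among the measurements shown bears on why the step is this large, so it stands as an observed result without an explanation.

A single pair cannot separate the contribution of the ring from that of the chlorine, and an unsubstituted phenyl group or a shorter chain such as butyl would be needed to tell them apart. From the compounds shown here alone, it also remains open whether a ring carrying an amine or a carboxylic acid would fit this position as well, and whether the same gain would appear with a different group on the other amide of the shared core.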